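This account rests on a few compounds, and the source may have more. Where it says the series, first, only, none or still open, it means among the compounds named here.

In a functional assay on PC-3 cells (Homo sapiens) for inhibition, read by MTT assay, with a stated time of 48 h (a higher number here means a weaker inhibitor of growth, a lower number a stronger inhibitor of growth), compound 2 `C#CCN(C)Cc1cccc(NC(=O)CCCCCCC(=O)NO)c1` gives 330 nM and compound 3 `C#CCN(C)Cc1cccc(NC(=O)CCCCCCCC(=O)NO)c1` gives 4070 nM, the higher of the two numbers. Compound 1 `C#CCN(C)Cc1cccc(NC(=O)CCCC(=O)NO)c1` reaches only the limit > 10000 nM in this assay. Compound 4 `C#CCN(C)Cc1cccc(NC(=O)CCCCCCCCC(=O)NO)c1` differs from compound 3 only in the chain that carries the hydroxycarbamoyl group: (hydroxycarbamoyl)methyl in place of hydroxycarbamoyl on a saturated chain carbon, seven bonds along the chain from a carbonyl carbon. The nearest guide is a 12-fold higher number from compound 2 to compound 3 (1.09 log units; beyond the scatter), where the same kind of lengthening weakened growth inhibition a great deal; the longer jumps an at least 30-fold lower number from compound 1 to compound 2 (1.48 log units; beyond the scatter) and an at least 2.4-fold lower number from compound 1 to compound 3 (0.39 log units; beyond the scatter) show that the shortest chain is weaker still, so among these compounds the best length sits at compound 2. A further lengthening is therefore expected to weaken compound 4 again, a 2.2-fold higher number from compound 3 to compound 4 (0.34 log units; beyond the scatter). Compound 4 is expected near 9000 nM, within 2500 nM to 30000 nM.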

Compound 4, concentration for 50% growth inhibition: 1790 nM
Compound 4: middle estimate off by 5.0-fold (0.70 log units), on the high side; measured number outside the range, below it.
By their numbers in this assay, from the lowest: compound 2; then compound 4; then compound 3. At a limit, above all of these: compound 1.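

In this assay, adding to the chain does not keep weakening growth inhibition: a 2.3-fold lower number from compound 3 to compound 4 (0.36 log units; beyond the scatter), so the rise in the number seen at the previous lengthening does not continue, and compound 3 stands out as a local worst point among the three longer chains. The gain still falls short of the best chain, with a 5.4-fold higher number from compound 2 to compound 4 (0.73 log units; beyond the scatter). The comparison with the shortest chain reads an at least 5.5-fold lower number from compound 1 to compound 4 (0.74 log units; beyond the scatter), and compound 1 is known only as a limit: the limit of > 10000 nM in this assay, at which 1 of the 4 values shown sits.

Open, going by these compounds, is whether a longer chain than that of compound 4 would lower the number further. Also open, on these data alone, is whether a carboxylic acid in place of hydroxycarbamoyl would keep any growth inhibition.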